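The source may hold more compounds than are shown below. What is called first, only, known or untested is meant among the compounds shown, and "the series" means these compounds.

Measured so far in a functional assay on A2780 cells (Homo sapiens) for cytotoxicity; a lower number here means a stronger inhibitor, a higher number a weaker inhibitor:
compound 1 `CCc1cnc(CSc2cnc(NC(C)=O)s2)o1`: 1400 nM
compound 2 `CC(C)OC(=O)Nc1ncc(SCc2ncc(C(C)(C)C)o2)s1`: 640 nM

Only these two numbers are available, and compound 2 has the lower one at 640 nM. Compound 1 reads 1400 nM, and the gap between them lies beyond the usual scatter, so compound 2 is the stronger of the pair. The two compounds differ in more than one place, so their gap cannot be tied to any single change.

Compound 3 `CC(C)(C)c1cnc(CSc2cnc(NC(=O)Nc3c(F)cccc3F)s2)o1` differs from compound 2 in one place: (2,6-difluorophenyl)amino stands in place of isopropoxy on a carbonyl carbon ((2,6-difluorophenyl)amino in place of isopropoxy on a carbonyl carbon). Among the measured compounds shown here, this is a large swap, and no measured pair shows what a change of this kind does in this assay. The starting point is therefore compound 2 at 640 nM, and no step beyond the scatter is expected, though real uncertainty remains in both directions. The estimated change is small, a 1.3-fold lower number from compound 2 to compound 3 (0.11 log units; within the scatter). For compound 3 the estimated value is 500 nM, with an expected range from 120 nM to 2200 nM.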

Compound 3, half-maximal inhibitory concentration: 240 nM
Estimate against measurement, compound 3: 2.1-fold (0.32 log units) above, within the range that was stated.
By their numbers in this assay, from the lowest: compound 3; then compound 2; then compound 1.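

On the carbonyl carbon, replacing isopropoxy with (2,6-difluorophenyl)amino in this assay gives a 2.7-fold lower number from compound 2 to compound 3 (0.43 log units; beyond the scatter) and so provides the first effect here that can be traced to a change in one place. The position therefore accepts a much larger group, one that brings an aromatic ring and a hydrogen-bond donor, and the number falls rather than rises. Nothing available explains why this step occurs.

This single swap changes several things at once: nitrogen replaces oxygen on the carbonyl carbon, and a ring and two fluorines arrive together, so the step cannot be divided among those parts. Going by these compounds, a plain phenylamino group without fluorine, or a short chain such as methylamino on the same carbonyl carbon, would help show whether the ring, the fluorines or the amino nitrogen matters most, and whether the gain extends beyond this one group remains open.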